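Dropping the Aromatic Methyl from Compound 1

The source may report more compounds than this note shows. Statements on the series, on what has been measured and on what is new or still open speak of the compounds shown alone.

Compound 1 `Cc1ccc2oc(-c3ccc(NC(=O)CN4CCN(CCCN(C)C)CC4)cc3)nc2c1` stands second highest of three numbers in a functional assay on A549 cells (Homo sapiens) for cytotoxicity, read by MTT assay, with a stated time of 24 h (a lower number here means a stronger inhibitor, a higher number a weaker inhibitor), at 10600 nM. Compound 2 `Cc1ccc2oc(-c3ccc(NC(=O)CN4CCN(CCCN(C)C)CC4)c(C)c3)nc2c1` gives 15300 nM, and compound 3 `Cc1ccc2oc(-c3ccc(NC(=O)CN4CCN(CCN(C)C)CC4)cc3)nc2c1` gives 3660 nM. The step of a 1.4-fold higher number from compound 1 to compound 2 (0.16 log units; within the scatter) went with a methyl in place of hydrogen on an aromatic carbon, while the step of a 2.9-fold lower number from compound 1 to compound 3 (0.46 log units; beyond the scatter) went with a change on the saturated chain. Compound 4 `CN(C)CCCN1CCN(CC(=O)Nc2ccc(-c3nc4ccccc4o3)cc2)CC1` differs from compound 1 by hydrogen in place of methyl on an aromatic carbon. The step from compound 1 to compound 2 is the closest guide, since it also concerns a methyl on an aromatic carbon and stayed within the scatter, so no step beyond the scatter is expected here. Compound 4 is expected at 10000 nM, between 5000 nM and 22000 nM, an expected step of a 1.1-fold lower number from compound 1 to compound 4 (0.03 log units; within the scatter).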

Compound 4, half-maximal inhibitory concentration: 18300 nM
The estimate for compound 4 lay 1.8-fold (0.26 log units) below the measured number; the range from low to high includes it.
By their numbers in this assay, from the lowest: compound 3; then compounds 1, 2 and 4 (each within the scatter of the next).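

In this assay the change from 5-methyl-1,3-benzoxazol-2-yl to 1,3-benzoxazol-2-yl gives a 1.7-fold higher number from compound 1 to compound 4 (0.24 log units; within the scatter) and so this methyl can be removed without a step beyond the scatter. Among these compounds, this is the first reading at this position, as the earlier methyl step concerned a different aromatic carbon. Nothing measured here explains the size of this step. As far as these compounds go, whether a larger group on this aromatic carbon, such as methoxy or a chlorine atom, would also stay within the scatter remains open.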